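This account rests on a few compounds, and the source may have more. Where it says the series, first, only, none or still open, it means among the compounds named here.

Compound 1 `Cc1nn(-c2nc(-c3ccc(Cl)c(Cl)c3)c(SC(C)C)s2)c(C(=O)O)c1-c1cccc(C(F)(F)F)c1` gives the highest number of the three measured compounds in a functional assay on BJAB cells (Homo sapiens) for antiproliferative activity, with a stated time of 4 days (on this read-out lower numbers stand for an effect already at smaller amounts and higher numbers for an effect only at larger amounts of compound), where compound 1 reaches 22000 nM. Compound 2 `Cc1nn(-c2nc(-c3ccc(Cl)c(Cl)c3)c(SC(C)C)s2)c(C(=O)O)c1-c1cc(C(F)(F)F)cc(C(F)(F)F)c1` bears an additional trifluoromethyl group and gives 1800 nM in this assay. Compound 3 `Cc1c(-c2cc(Cl)cc(Cl)c2)c(C(=O)O)nn1-c1nc(-c2cc(Cl)cc(Cl)c2)c(SC(C)C)s1` differs from compound 1 in several places, and in this assay compound 3 gives 2000 nM. Among the compounds with values here, the only single-point step among the measured compounds is a 12-fold lower number from compound 1 to compound 2 (1.09 log units; beyond the scatter), and it shows that the substitution on the aryl group attached to the core can move the number strongly.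

Compound 4 `CC(=O)Nc1ccc(-c2c(C)nn(-c3nc(-c4ccc(Cl)c(Cl)c4)c(SC(C)C)s3)c2C(=O)O)cc1` differs from compound 1 by 4-acetamidophenyl in place of 3-(trifluoromethyl)phenyl on an aromatic carbon. Within the data shown here, no measured step covers this replacement: the one step that alters this ring adds a trifluoromethyl group rather than exchanging one for an acetamido group, so its size cannot be carried over, and it tells only that this part of the molecule matters. With no evidence for a direction, compound 4 is expected to stay close to where compound 1 stands, with a wide band on either side. Compound 4 is therefore expected to show a step of a 1.1-fold lower number from compound 1 to compound 4 (0.04 log units; within the scatter). Compound 4 is estimated at 20000 nM, within 5000 nM to 80000 nM.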

Compound 4, half-maximal effective concentration: 139000 nM
Beside the measured number, compound 4's estimate is 7.0-fold (0.84 log units) below it; the measured number lies above the stated range.
By their numbers in this assay, from the lowest: compounds 2 and 3 (each within the scatter of the next); then compound 1; then compound 4.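

In this assay, the exchange of 3-(trifluoromethyl)phenyl for 4-acetamidophenyl gives a 6.3-fold higher number from compound 1 to compound 4 (0.80 log units; beyond the scatter), so the number at this position can also move upward, whereas the earlier step on this ring, a 12-fold lower number from compound 1 to compound 2 (1.09 log units; beyond the scatter), went the other way. With compound 2 and compound 4 now on opposite sides of compound 1, the aryl group on this aromatic carbon can shift the number in either direction, although this exchange removes the trifluoromethyl group, brings in the acetamido group and changes where the substituent sits on the ring all at once, so the step cannot be assigned to any one of these alone. Nothing among the available data accounts for the size or direction of this step.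

The compounds shown leave open how an unsubstituted phenyl group would stand against compound 1 and compound 4, and so whether the higher number of compound 4 reflects the loss of the trifluoromethyl group or the arrival of the acetamido group. They also leave open how an amine, a methoxy group or a carboxylic acid on this ring would compare.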